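The compounds below may be only part of what the source reports. "The series", "measured", "known", "first", "only" and "open" are said of these compounds alone.

Compound 1 `OCc1cn(Cc2ccc(Cl)cc2)c2ccccc12` is the reference point of this small set. In an ADME assay on T29 cells (Homo sapiens) for cytotoxicity, read by sulforhodamine B assay, with a stated time of 3 days (a higher number here means a weaker inhibitor, a lower number a stronger inhibitor), compound 1 gives > 31600 nM, which is a limit of the assay rather than a number. Compound 2 `COc1ccc(Cn2cc(CO)c3ccccc32)cc1` differs from compound 1 by methoxy in place of chloro on an aromatic carbon. In this assay compound 2 gives > 31600 nM, again a limit. The step that the two limits leave unreadable from compound 1 to compound 2 therefore cannot be sized. Compound 3 `OCc1cn(Cc2ccc(Cl)cc2)c2ccc(Cl)cc12` differs from compound 1 by chloro in place of hydrogen on an aromatic carbon, and this is also the difference between the core of compound 3 and the core of compound 1. In this assay compound 3 gives > 31600 nM, once more a limit. The step that the two limits leave unreadable from compound 1 to compound 3 is likewise not readable. What the set shows is the limit of > 31600 nM in this assay, at which 3 of the 3 values shown sit.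

Compound 4 `COc1ccc2c(c1)c(CO)cn2Cc1ccc(Cl)cc1` has not yet been measured. It differs from compound 3 by methoxy in place of chloro on an aromatic carbon. Among the compounds with values here, this is the same kind of change as the one from compound 1 to compound 2, though the surroundings differ: in compound 1 the changed carbon is para to a large group, whereas in compound 3 it is part of a fused or bridged system of two rings, meta to a fused ring and para to a fused ring.

For compound 4 the expected step is a step that the limit leaves unreadable from compound 3 to compound 4, an estimate that rests on the unreadable step that the two limits leave unreadable from compound 1 to compound 2 and on the fact that the limit of > 31600 nM in this assay, at which 3 of the 3 values shown sit, holds for every measured compound. Compound 4 is accordingly estimated at 45000 nM in this assay, with a range from 20000 nM to 100000 nM, and most likely a limit will again be reported.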

Compound 4, half-maximal inhibitory concentration: > 31600 nM
Compound 4 was reported as a limit (the forecaster's own chance of this, stated with the estimate: 85%); the middle value is on the limit's open side.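

In this assay compound 4 gives > 31600 nM, again a limit, so no new step can be read, neither from compound 3 to compound 4 nor from compound 1 to compound 4. The four compounds leave open whether any of these changes on the shared core alters the half-maximal inhibitory concentration at all, and what they offer is only this: the limit of > 31600 nM in this assay, at which 4 of the 4 values shown sit.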